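Growth inhibition series on the shared core: compound 4 ahead

This account rests on a few compounds, and the source may have more. Where it says the series, first, only, none or still open, it means among the compounds named here.

Measured compounds:
- compound 1: `CN(C)c1ccc(/C=C(/SCc2ccc(Cl)cc2Cl)C(=O)c2ccc(Cl)cc2)cc1`, 50000 nM
- compound 2: `CN(C)c1ccc(/C=C(/SCc2ccc(F)cc2)C(=O)c2ccc(Br)cc2)cc1`, 50000 nM
- compound 3: `CCOc1ccc(/C=C(/Sc2ccc(C)cc2)C(=O)c2ccc(Cl)cc2)cc1OC`, 25000 nM

In a functional assay on DU-145 cells (Homo sapiens) for inhibition, read by trypan blue exclusion, with a stated time of 96 h (a higher number here means a weaker inhibitor of growth, a lower number a stronger inhibitor of growth), compound 1 gives 50000 nM. In this assay compound 2 gives 50000 nM, level with compound 1 at the digits shown, and the two sit together at the high end of the three numbers. In this assay compound 3 gives 25000 nM, a lower number than compound 2, but the gap between them lies within the scatter, so no order between the three can be read from these values.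

Compound 4, `O=C(/C(=C\c1ccc(O)cc1)SCc1ccc(F)cc1)c1ccc(Br)cc1`, is not yet measured. It differs from compound 2 in one place: hydroxy in place of dimethylamino on an aromatic carbon. Among the measured compounds shown here, no step between measured compounds covers this change, so nothing in the measured set tells how much a hydroxy in place of a dimethylamino moves the number. The expectation is a step from compound 2 to compound 4 of a 1.3-fold lower number from compound 2 to compound 4 (0.10 log units; within the scatter), not beyond the scatter in either direction. Compound 4 is therefore expected to give 40000 nM in this assay, with a range from 15000 nM to 100000 nM.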

Compound 4, concentration for 50% growth inhibition: 10000 nM
For compound 4 the middle estimate is 4.0-fold (0.60 log units) above the measured one; the measured number lies below the stated range.
By their numbers in this assay, from the lowest: compound 4; then compounds 3, 1 and 2 (each within the scatter of the next).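

In this assay, among the compounds shown here, the change from 4-(dimethylamino)phenyl to 4-hydroxyphenyl gives a 5.0-fold lower number from compound 2 to compound 4 (0.70 log units; beyond the scatter) and is the only step so far, so the group on this aromatic carbon, para to a large group, can move the number. The earlier compounds shown here differed in more than one place and could not show this. The hydroxy brings a hydrogen-bond donor that the dimethylamino lacks and is also the smaller group, and no measurement available here bears on what lies behind the step.

A single pair leaves open whether the donor or the size of the group tracks with the number, which an amino group or a carboxylic acid at this position could help to separate. On these data alone, whether the step carries over to the other groups on the shared core also remains open.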